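The compounds below may be only part of what the source reports. "The series", "measured", "known", "first", "only" and "open" are said of these compounds alone.

Of the compounds shown here, three built on one shared core have been measured in a functional assay on MGC-803 cells (Homo sapiens) for antiproliferative activity, read by MTT assay, with a stated time of 48 h; a higher number here means a weaker inhibitor, a lower number a stronger inhibitor. Compound 1 `COc1ccc(CN(C(=O)CSc2nc3ccccc3s2)c2cc(OC)c(OC)c(OC)c2)cc1C` gives 6360 nM. Compound 2 `COc1ccc(CN(C(=O)CSc2nc3ccccc3s2)c2cc(OC)c(OC)c(OC)c2)cc1O` gives 35 nM. Compound 3 `COc1cc(N(Cc2ccc(Br)cc2)C(=O)CSc2nc3ccccc3s2)cc(OC)c1OC` gives 48100 nM, the highest number of the three and so the weakest inhibitor of this set; the two measured steps that end at it are a 7.6-fold higher number from compound 1 to compound 3 (0.88 log units; beyond the scatter) and a 1400-fold higher number from compound 2 to compound 3 (3.14 log units; beyond the scatter).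

Compound 4 `COc1ccc(CN(C(=O)CSc2nc3ccccc3s2)c2cc(OC)c(OC)c(OC)c2)cc1C(F)(F)F` has not yet been measured in this assay. It differs from compound 3 in one place: 4-methoxy-3-(trifluoromethyl)phenyl in place of 4-bromophenyl on a saturated chain carbon bound to an amide-type nitrogen.

Both measured steps bear on this change, since each swaps the same 4-bromophenyl for a ring carrying a methoxy group. Where the partner group was a methyl, the step was modest; where it was a hydroxy, the step was large. The ring entering in compound 4 carries a trifluoromethyl and no hydroxy, so the expectation leans on compound 1 rather than compound 2. Compound 4 is therefore expected to show a modestly lower number than compound 3, estimated as a 6.0-fold lower number from compound 3 to compound 4 (0.78 log units; beyond the scatter). In this assay compound 4 is expected to give 8000 nM, with a likely range from 2000 nM to 40000 nM.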

Compound 4, half-maximal inhibitory concentration: 25200 nM
Estimate against measurement, compound 4: 3.2-fold (0.50 log units) below; the range from low to high includes it.
By their numbers in this assay, from the lowest: compound 2; then compound 1; then compounds 4 and 3 (each within the scatter of the next).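

In this assay, the swap of the whole ring gives a 1.9-fold lower number from compound 3 to compound 4 (0.28 log units; within the scatter), so 4-methoxy-3-(trifluoromethyl)phenyl and 4-bromophenyl cannot be told apart here, and a ring carrying a methoxy group does not by itself set a compound clear of compound 3. Holding everything else fixed and changing only the group on one aromatic carbon, trifluoromethyl in place of methyl gives a 4.0-fold higher number from compound 1 to compound 4 (0.60 log units; beyond the scatter), while trifluoromethyl in place of hydroxy gives a 720-fold higher number from compound 2 to compound 4 (2.86 log units; beyond the scatter), so among the three groups seen on this carbon, the low number of compound 2 goes with hydroxy alone, and methyl and trifluoromethyl both leave the compound far from it. Nothing in the data shown gives a reason for these differences.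

On these data alone, whether another group on this carbon, such as an amine, a carboxylic acid or a hydroxymethyl, would come close to compound 2 remains open. Also open, as far as these compounds go, is whether the hydroxy would keep its large effect on a ring without the methoxy group, or with a different core.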